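The source may hold more compounds than are shown below. What is called first, only, known or untested is meant among the compounds shown, and "the series" means these compounds.

Measured so far in a physicochemical assay for solubility, read by HPLC, in phosphate buffer, measured as kinetic solubility, at pH 7.4; on this read-out lower numbers stand for lower solubility and higher numbers for higher solubility:
- Compound 1 `Cc1ccc(-c2ccc(Cl)cc2)n1-c1ccc(S(N)(=O)=O)cc1` gives 6100 nM 
- Compound 2 `NS(=O)(=O)c1ccc(-c2cc(C(=O)C3CCC3)nn2-c2ccc(Cl)cc2)cc1` gives 17200 nM 
- Compound 3 `CCC(=O)c1cc(-c2ccc(S(N)(=O)=O)cc2)n(-c2ccc(C(F)(F)F)cn2)n1` gives 99400 nM 

Compound 2 holds the middle place of the three. Its nearest neighbour on the numbers is compound 1, which lies lower, and its furthest is compound 3, which lies higher. Both gaps are beyond the scatter.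

Compound 4 `CN(C(=O)c1cc(-c2ccc(S(N)(=O)=O)cc2)n(-c2ccc(Cl)cc2)n1)C1CC1` has not yet been measured. Compared with compound 2, it carries cyclopropyl(methyl)amino in place of cyclobutyl on a carbonyl carbon, so that cyclobutylcarbonyl becomes cyclopropyl(methyl)carbamoyl.

Among the compounds with values here, no two measured compounds differ in one place only, so the data offer no direct guide to this change, and the wide spread among the three compounds leaves the forecast loose. In this assay a small rise is expected, with the estimated step (a 1.5-fold higher number from compound 2 to compound 4 (0.18 log units; within the scatter)) not clearly beyond the scatter. For compound 4 the estimated value is 26000 nM (expected range 9000 nM to 75000 nM).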

Compound 4, solubility: 99600 nM
Estimate against measurement, compound 4: 3.8-fold (0.58 log units) below; measured number above the stated range.
By their numbers in this assay, from the lowest: compound 1; then compound 2; then compounds 3 and 4 (each within the scatter of the next).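

Within the data shown here, this is the first single-place comparison in the set. In this assay, putting cyclopropyl(methyl)amino in place of cyclobutyl on a carbonyl carbon gives a 5.8-fold higher number from compound 2 to compound 4 (0.76 log units; beyond the scatter), so this position can move the read-out beyond the scatter. The change from cyclobutylcarbonyl to cyclopropyl(methyl)carbamoyl is tied to higher solubility here, but no measurement in hand explains the step.

The compounds shown leave open which part of the entering group carries the step: the nitrogen, the methyl or the three-membered ring. They also leave open whether another group on the same carbonyl carbon, such as dimethylamino, morpholine or a plain cyclopropyl, would move the read-out as far.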